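The compounds below may be only part of what the source reports. "The series", "measured", "known", "first", "only" and "open" are said of these compounds alone.

Measured compounds:
compound 1 `CNc1nc(Nc2ccc(C#N)cc2)nc(Oc2ccc3ccccc3c2)n1`: 250000 nM
compound 2 `CC(C)Nc1nc(Nc2ccc(C#N)cc2)nc(Oc2ccc3ccccc3c2Br)n1`: 41500 nM

In an ADME assay on MT4 cells (Homo sapiens) for cytotoxicity, read by MTT assay, with a stated time of 4 days (a lower number here means that less compound is tolerated, a higher number that more compound is tolerated), compound 2 gives 41500 nM, the lowest of the two numbers; the nearest is compound 1, which in this assay gives 250000 nM, a gap beyond the scatter. Compound 3 `CNc1nc(Nc2ccc(C#N)cc2)nc(Oc2ccc3ccccc3c2Br)n1` has not yet been measured. It differs from compound 2 by methyl in place of isopropyl on a nitrogen on an aromatic ring. For the measured compounds named here, no measured pair shows this change on its own; compound 1 and compound 2 differ in two places, so their gap cannot be assigned to either change. With nothing to rest on except the two numbers shown, the step from compound 2 to compound 3 in this assay is expected to be modest and to run toward a higher number, so that compound 3 is expected to sit between the two measured values; the estimated step is a 2.0-fold higher number from compound 2 to compound 3 (0.31 log units; beyond the scatter). Compound 3 is thus estimated at 85000 nM, with a range from 30000 nM to 250000 nM.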

Compound 3, half-maximal cytotoxic concentration: 143000 nM
Compound 3: the middle estimate sits 1.7-fold (0.23 log units) below what was measured; the measured number falls inside the stated range.
By their numbers in this assay, from the lowest: compound 2; then compounds 3 and 1 (each within the scatter of the next).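

In this assay the change from isopropyl to methyl on a nitrogen on an aromatic ring can now be read on its own, with the bromo group held in place, as a 3.4-fold higher number from compound 2 to compound 3 (0.54 log units; beyond the scatter) and so beyond the scatter. For the compounds shown here, the other single change, bromo in place of hydrogen on an aromatic carbon, can also be read alone for the first time, with the methylamino group held in place: a 1.7-fold lower number from compound 1 to compound 3 (0.24 log units; within the scatter) stays within the scatter. Going by these compounds alone, of the two changes that could not be separated before, only the one on the nitrogen gives a step beyond the scatter in these compounds.

The compounds shown leave open whether ethyl, a longer chain or a cyclopropyl ring on that nitrogen would follow the same direction, and whether chloro in place of bromo would also stay within the scatter. Nothing measured here offers an explanation for either step.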